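Chain extension in a chlorinated carbamate series: stability notes

The source may report more compounds than this note shows. Statements on the series, on what has been measured and on what is new or still open speak of the compounds shown alone.

Three members of the series have been run in an ADME assay for metabolic stability, read by HPLC, at pH 7; on this read-out higher numbers stand for a longer-lived compound and lower numbers for a shorter-lived compound. Compound 1 `CCCCCNC(=O)Oc1ccc(Cl)cc1C(=O)Nc1cccc(Cl)c1` gives 64 h, compound 2 `CCCCCCNC(=O)Oc1ccc(Cl)cc1C(=O)Nc1cccc(Cl)c1` gives 64 h and compound 3 `CCCCCCNC(=O)Oc1ccc(Cl)cc1C(=O)Nc1ccc(Cl)cc1` gives 64 h. The change methyl in place of hydrogen on a saturated chain carbon, five bonds along the chain from an amide-type nitrogen made the step of no change at the digits printed from compound 1 to compound 2 (within the scatter), and the further step no change at the digits printed from compound 2 to compound 3 (within the scatter) likewise stayed flat. The difference between the cores of compound 1 and compound 3 is not broken down here.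

Compound 4 `CCCCCCCNC(=O)Oc1ccc(Cl)cc1C(=O)Nc1ccc(Cl)cc1` carries the change (methyl in place of hydrogen on a saturated chain carbon, six bonds along the chain from an amide-type nitrogen), the same kind of change as from compound 1 to compound 2, set one bond further along the chain: six bonds from the amide-type nitrogen rather than five. Resting on compound 1 and compound 2, where no change at the digits printed from compound 1 to compound 2 (within the scatter), the step is expected to be no change at the digits printed from compound 3 to compound 4 (within the scatter). Compound 4 is therefore estimated at 64 h in this assay, between 32 h and 128 h.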

Compound 4, half-life: 64 h
The estimate for compound 4 equals the measured number at the digits printed; low and high end bracket the measured number.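

The step on the core of compound 3 reads, in this assay, no change at the digits printed from compound 3 to compound 4 (within the scatter), and it sits beside the earlier chain step as follows: the same change on two cores in this assay, no change at the digits printed (within the scatter) from compound 1 to compound 2 and no change at the digits printed (within the scatter) from compound 3 to compound 4, 1.0-fold (0.00 log units) apart, within the scatter of two such steps

On these two cores the change therefore carries over with no visible difference, although it sits five bonds along the chain in one case and six bonds along in the other. Two flat steps show only this much; they do not show how the change would behave on any other core, or on a core where it moves the half-life.

Still open, from the compounds shown here alone, is whether a longer chain, a branched chain, or a chain ending in an amine or a carboxylic acid would also read level in this assay. Also open, going by these compounds, is what a fluorine in place of either chlorine would do.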